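A few compounds are considered here, and "the series" means these few. Any claim that something is new, unique, unknown or untested is made for them only; others in the source may bear on it.

In an assay on brain for displacement of a labelled ligand from Adrenergic receptor alpha-1 (Rattus norvegicus) (on this read-out lower numbers stand for stronger inhibition and higher numbers for weaker inhibition), three close analogues sharing one core have been measured. Compound 1 `COCCOC1CCN(c2nc(N)c3cc(OC)c(OC)cc3n2)CC1` gives 2.12 nM, compound 2 `CCCCOCCOC1CCN(c2nc(N)c3cc(OC)c(OC)cc3n2)CC1` gives 1.03 nM, and compound 3 `COc1cc2nc(N3CCC(OCC(C)OC)CC3)nc(N)c2cc1OC` gives 1.41 nM. Among these three numbers compound 3 stands second highest; its nearest neighbour is compound 2 and its furthest is compound 1, and both gaps lie within the usual scatter of repeated measurements, so the three compounds cannot be placed in a firm order.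

Compound 4 `CCOC(C)COC1CCN(c2nc(N)c3cc(OC)c(OC)cc3n2)CC1` differs from compound 3 by methyl in place of hydrogen on a saturated chain carbon bound to an oxygen on a saturated carbon. Among the measured compounds shown here, two measured steps touch the same kind of carbon and so bear on this change. a 2.1-fold lower number from compound 1 to compound 2 (0.31 log units; beyond the scatter) puts a propyl there and brings a modest drop in the number, beyond the scatter. a 1.5-fold lower number from compound 1 to compound 3 (0.18 log units; within the scatter) puts a methyl there and stays within the scatter. The change from compound 3 to compound 4 adds a methyl, closer in kind to the second step than to the first, so the expected effect in this assay is small: at most a slight lowering of the number, most likely within the scatter.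

Compound 4 is therefore estimated at 1.2 nM in this assay, with a range from 0.6 nM to 2.5 nM, and the expected step is a 1.2-fold lower number from compound 3 to compound 4 (0.07 log units; within the scatter).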

Compound 4, inhibition constant: 0.99 nM
The estimate for compound 4 lay 1.2-fold (0.08 log units) above the measured number, and the stated range covers the measured number.
By their numbers in this assay, from the lowest: compounds 4, 2, 3 and 1 (each within the scatter of the next, the first and the last beyond it).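

In this assay, a methyl on this saturated chain carbon of compound 3, which turns 1-methoxyethyl into 1-ethoxyethyl, gives a step that stays within the scatter (a 1.4-fold lower number from compound 3 to compound 4 (0.15 log units; within the scatter)), so this small addition brings no change that can be told apart from repeat-to-repeat noise. The branched 1-ethoxyethyl group and the unbranched butoxymethyl group cannot be told apart either (a 1.0-fold lower number from compound 2 to compound 4 (0.02 log units; within the scatter)). Only against the methoxymethyl group of compound 1 does a real difference appear, a modest one beyond the scatter (a 2.1-fold lower number from compound 1 to compound 4 (0.33 log units; beyond the scatter)), so compound 2 and compound 4 both clear the scatter from compound 1, while compound 3 does not.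

Nothing available explains why these ether chains give such similar numbers. On these data alone, it remains open whether an amine or a carboxylic acid at the end of this chain would keep the number this low, and whether a chain longer than butoxymethyl would do so.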